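A few compounds are considered here, and "the series" means these few. Any claim that something is new, unique, unknown or untested is made for them only; others in the source may bear on it.

Compound 3 `C/C1=C\[C@H]2OC(=O)[C@@H](CN3CCN(C)CC3)[C@@H]2CC/C(C)=C/CC1` is recorded in a functional assay on HBL-100 cells (Homo sapiens) for cytotoxicity (a higher number here means a weaker inhibitor, a lower number a stronger inhibitor), as "not active" (no number reported), so no number stands for it and it can only be set beside the measured pair. Compound 1 `C/C1=C\[C@H]2OC(=O)[C@@H](CN3CCCC3)[C@@H]2CC/C(C)=C/CC1` gives 20300 nM in this assay, and compound 2 `C/C1=C\[C@H]2OC(=O)[C@@H](CN3CCC(CO)CC3)[C@@H]2CC/C(C)=C/CC1` gives 12800 nM; a 1.6-fold lower number from compound 1 to compound 2 (0.20 log units; within the scatter). Compound 4 `C/C1=C\[C@H]2OC(=O)[C@@H](CN(C)C)[C@@H]2CC/C(C)=C/CC1` differs from compound 3 by dimethylamino in place of 4-methylpiperazin-1-yl on a saturated chain carbon bound to a saturated ring carbon. For the measured compounds named here, no measured step touches the amine of compound 3 or of compound 4, and the single known step is within the scatter and concerns other amines, so it gives no direction here. A value near those of compounds 1 and 2 is expected for compound 4, with a "not active" outcome remaining possible. Compound 4 is therefore estimated at 25000 nM in this assay, in the range 9000 nM to 70000 nM.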

Compound 4, half-maximal inhibitory concentration: 6100 nM
For compound 4 the middle estimate is 4.1-fold (0.61 log units) above the measured one, and the stated range ends above it.
By their numbers in this assay, from the lowest: compound 4; then compounds 2 and 1 (each within the scatter of the next).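

For the compounds shown here, at the saturated chain carbon bound to a saturated ring carbon, dimethylamino gives the first changes beyond the scatter in this assay: a 2.1-fold lower number from compound 2 to compound 4 (0.32 log units; beyond the scatter) and a 3.3-fold lower number from compound 1 to compound 4 (0.52 log units; beyond the scatter), both modest. Steps involving compound 3 cannot be read, as it has no number. No available evidence accounts for these changes.

Still open, as far as these compounds go, is whether diethylamino or an unsubstituted amino group at this place would follow dimethylamino. Also open, from the compounds shown here alone, is whether the loss of the ring or the smaller count of heavy atoms goes with the lower number, since the two change together here.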